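This account rests on a few compounds, and the source may have more. Where it says the series, first, only, none or still open, it means among the compounds named here.

Working notes on the series. The common core carries a propanoic acid on one ring and a benzyloxy link to a second aromatic ring. In a functional assay on cells for agonist activity at Free fatty acid receptor 1 (Homo sapiens), read by FLIPR and calcium flux (on this read-out higher numbers stand for larger maximal responses and lower numbers for smaller maximal responses), compound 1, `Cc1cc(CCC(=O)O)ccc1OCc1cccc(Oc2ccccc2)c1`, gives 90%. Compound 2, `Cc1cc(C)cc(COc2ccc(CCC(=O)O)cc2C)c1`, gives 97% in this assay. The two numbers lie within the usual scatter of each other, so neither compound can be placed above the other on this read-out; compound 2 stands at the same level as compound 1 as far as the data go.

The next compound, compound 3, `Cc1cc(COc2ccc(CCC(=O)O)cc2C)cc(Oc2ccccc2)c1`, has not yet been measured in this assay. Relative to compound 2 the change is phenoxy in place of methyl on an aromatic carbon. Among the measured compounds shown here, no measured pair shows the effect of this exact change, so the expectation rests on the two numbers at hand, which are close to each other and both near the upper end of the scale.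

A step from compound 2 to compound 3 of a number 4 percentage points lower from compound 2 to compound 3 (within the scatter) in this assay is expected, that is, none beyond the scatter. Compound 3 is estimated at 93%, with a range of 80% to 105%.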

Compound 3, largest response reached (reported as percent of maximum), in percent of the reference or control that the assay uses: 85%
For compound 3 the middle estimate is 8 percentage points above the measured one, within the range that was stated.
By their numbers in this assay, from the lowest: compounds 3, 1 and 2 (each within the scatter of the next, the first and the last beyond it).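

In this assay the exchange of methyl for phenoxy on an aromatic carbon, at a place meta to a large group and meta to a methyl group, gives a number 12 percentage points lower from compound 2 to compound 3 (beyond the scatter) as a modest step, the only step beyond the scatter among the compounds shown. The position therefore takes the larger group with its aromatic ring while compound 3 still gives 85% in this read-out, so the response is lowered but far from lost. With phenoxy in place, methyl in place of hydrogen on an aromatic carbon gives a number 5 percentage points lower from compound 1 to compound 3 (within the scatter) and so shows no effect that can be told apart from repeat measurements. No evidence on hand speaks to the reason for either step.

Still open, as far as these compounds go, is whether another group at this place, such as an amine, a carboxylic acid or a longer alkyl chain, would keep the response at the level of compound 2 or lower it further. Among the compounds shown here, the single pair also leaves open whether the modest step belongs to the phenoxy group in general or only to its combination with the methyl group on the same ring.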